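A few compounds are considered here, and "the series" means these few. Any claim that something is new, unique, unknown or untested is made for them only; others in the source may bear on it.

Three compounds share one core and differ only in the group on the aromatic carbon of the fused two-ring system. Compound 1 `Cc1c(C(=O)Nc2ccc(Oc3ncnc4[nH]cc(-c5ccccc5)c34)c(F)c2)c(=O)c2cc(Cl)ccc2n1C` carries a chloro there and in an assay on isolated protein for inhibition of tyrosine-protein kinase receptor UFO (Homo sapiens), read by FRET and Z'-LYTE, with a stated time of 1.5 h (a lower number here means a stronger inhibitor, a higher number a weaker inhibitor), compound 1 gives 1890 nM. Compound 2 `Cc1c(C(=O)Nc2ccc(Oc3ncnc4[nH]cc(-c5ccccc5)c34)c(F)c2)c(=O)c2cc(Br)ccc2n1C` carries a bromo, and in this assay compound 2 gives 3120 nM; the step of a 1.7-fold higher number from compound 1 to compound 2 (0.22 log units; within the scatter) stays within the scatter. Compound 3 `Cc1c(C(=O)Nc2ccc(Oc3ncnc4[nH]cc(-c5ccccc5)c34)c(F)c2)c(=O)c2cc(C(F)(F)F)ccc2n1C` carries a trifluoromethyl, and in this assay compound 3 gives 150 nM, the lowest number of the three and therefore the strongest inhibitor of this set, as both a 13-fold lower number from compound 1 to compound 3 (1.10 log units; beyond the scatter) and a 21-fold lower number from compound 2 to compound 3 (1.32 log units; beyond the scatter) lie well beyond the scatter.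

Compound 4 `CCc1ccc2c(c1)c(=O)c(C(=O)Nc1ccc(Oc3ncnc4[nH]cc(-c5ccccc5)c34)c(F)c1)c(C)n2C` is the next step from compound 3: ethyl in place of trifluoromethyl on an aromatic carbon. Going by the values given here, no measured pair shows an ethyl at this position, so the two large steps leading to the trifluoromethyl are the only guide. Both show that this position governs the number strongly and that the trifluoromethyl is the best of the three groups tried, so a change away from it is expected to raise the number, though an ethyl is neither a halogen nor a trifluoromethyl and the size of the rise is uncertain. The step for compound 4 is therefore estimated as a 3.3-fold higher number from compound 3 to compound 4 (0.52 log units; beyond the scatter). In this assay compound 4 is expected to give about 500 nM, with a likely range from 120 nM to 2000 nM.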

Compound 4, half-maximal inhibitory concentration: 6 nM
For compound 4 the middle estimate is 83-fold (1.92 log units) above the measured one; the whole stated range lies above it.
By their numbers in this assay, from the lowest: compound 4; then compound 3; then compounds 1 and 2 (each within the scatter of the next).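

Compound 4, with an ethyl, is the strongest inhibitor of the four, and the step of a 25-fold lower number from compound 3 to compound 4 (1.40 log units; beyond the scatter) shows that the trifluoromethyl did not mark the best this position can give. Going by these compounds alone, the steps of a 520-fold lower number from compound 2 to compound 4 (2.72 log units; beyond the scatter) and a 320-fold lower number from compound 1 to compound 4 (2.50 log units; beyond the scatter) show that the range of this position in this assay is far wider than the three earlier compounds suggested, and that the only group here without a halogen gives the lowest number. Nothing available on the properties of these groups or on how the compounds behave accounts for this order, so the result stands as an observation without an explanation.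

The compounds shown leave open whether the gain is particular to the ethyl or extends to a methyl, a longer chain such as propyl, or a branched or cyclic group such as isopropyl or cyclopropyl, and how a methoxy or an amine would compare at this position. They also leave open whether the same order would hold with a different group elsewhere on the shared core.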